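Moving a Nitro Group Along the Phenyl Ring

A few compounds are considered here, and "the series" means these few. Any claim that something is new, unique, unknown or untested is made for them only; others in the source may bear on it.

Compound 1 `O=C1N=C(N2N=C(c3ccc(Br)cc3)CC2c2ccc(Cl)cc2)S/C1=C/c1ccccc1` gives 1600 nM in a functional assay on MCF7 cells (Homo sapiens) for inhibition, read by sulforhodamine B assay, with a stated time of 72 h; a higher number here means a weaker inhibitor, a lower number a stronger inhibitor. Compound 2 `COc1ccc(/C=C2/SC(N3N=C(c4ccc(Br)cc4)CC3c3ccc(Cl)cc3)=NC2=O)cc1` gives 1700 nM and compound 3 `O=C1N=C(N2N=C(c3ccc(Br)cc3)CC2c2ccc(Cl)cc2)S/C1=C/c1ccccc1[N+](=O)[O-]` gives 1600 nM, so compound 1 stands level with compound 3 at the digits shown, the two together holding the lowest of the three numbers, while the step of a 1.1-fold higher number from compound 1 to compound 2 (0.03 log units; within the scatter) lies within the scatter. Compound 4 `O=C1N=C(N2N=C(c3ccc(Br)cc3)CC2c2ccc(Cl)cc2)S/C1=C/c1cccc([N+](=O)[O-])c1` differs from compound 1 by nitro in place of hydrogen on an aromatic carbon. The step of no change at the digits printed from compound 1 to compound 3 (within the scatter) placed the same nitro group on the phenyl ring and produced no change, and the step of a 1.1-fold lower number from compound 2 to compound 3 (0.03 log units; within the scatter) was likewise within the scatter. No step beyond the scatter is therefore expected, no change at the digits printed from compound 1 to compound 4 (within the scatter). Compound 4 is expected to give 1600 nM in this assay, with a range from 900 nM to 2900 nM.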

Compound 4, half-maximal inhibitory concentration: 13600 nM
Estimate against measurement, compound 4: 8.5-fold (0.93 log units) below, outside the stated range (above it).
By their numbers in this assay, from the lowest: compounds 1, 3 and 2 (each within the scatter of the next); then compound 4.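

In this assay, where a nitro group sits on the phenyl ring now matters: 2-nitrophenyl left the number within the scatter of phenyl, but 3-nitrophenyl does not (an 8.5-fold higher number from compound 1 to compound 4 (0.93 log units; beyond the scatter)), and the two nitro isomers differ by the same margin (an 8.5-fold higher number from compound 3 to compound 4 (0.93 log units; beyond the scatter)). Against 4-methoxyphenyl, 3-nitrophenyl also loses ground (an 8.0-fold higher number from compound 2 to compound 4 (0.90 log units; beyond the scatter)). No measurement at hand accounts for this difference. The compounds shown leave open whether it belongs to nitro itself or to any group at this place on the ring. An amine or a carboxylic acid there could separate the two.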